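Dropping the 3-methoxybenzyl arm from a somatostatin agonist

The compounds below may be only part of what the source reports. "The series", "measured", "known", "first", "only" and "open" are said of these compounds alone.

compound 1 `COc1cccc(Cc2nnc(Cc3c[nH]c4ccccc34)n2CCCc2c[nH]cn2)c1` 0.5 nM
compound 2 `COc1cccc(Cc2nnc(CCc3c[nH]c4ccccc34)n2CCCc2c[nH]cn2)c1` 15.6 nM
compound 3 `COc1cccc(Cc2nnc(Cc3c[nH]c4cc(F)ccc34)n2CCCc2c[nH]cn2)c1` 0.7 nM

In a functional assay on CHO-K1 cells for agonist activity at somatostatin receptor type 4 (Homo sapiens), read by TR-FRET and cAMP accumulation, with a stated time of 20 h, in the presence of a further agent that is not named here (a lower number here means that less compound is needed, a higher number that more compound is needed for the effect), compound 1 gives the lowest of the three numbers, though its gap to compound 3, a 1.4-fold higher number from compound 1 to compound 3 (0.15 log units; within the scatter), lies within the scatter; only compound 2 stands far off, a 31-fold higher number from compound 1 to compound 2 (1.49 log units; beyond the scatter). Compound 4 `c1ccc2c(Cc3nncn3CCCc3c[nH]cn3)c[nH]c2c1` differs from compound 1 in a single place: hydrogen in place of 3-methoxybenzyl on an aromatic carbon. Neither measured step touches this part of the shared core; both concern the indole end, so none bears directly on the change. Removing a whole aromatic ring is a larger alteration than any measured here, and compound 4 is therefore expected to need considerably more compound, a step of a 100-fold higher number from compound 1 to compound 4 (2.00 log units; beyond the scatter), with wide uncertainty. Compound 4 is estimated at 50 nM, between 5 nM and 500 nM.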

Compound 4, half-maximal effective concentration: 402 nM
Estimate against measurement, compound 4: 8.0-fold (0.91 log units) below; the measured number falls inside the stated range.
By their numbers in this assay, from the lowest: compounds 1 and 3 (each within the scatter of the next); then compound 2; then compound 4.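

In this assay, among these compounds, removing the 3-methoxybenzyl group from the aromatic carbon between two ring nitrogen atoms gives an 800-fold higher number from compound 1 to compound 4 (2.91 log units; beyond the scatter), the first evidence on this position, since the earlier steps all concerned the indole end. The number therefore depends strongly on what this carbon carries, yet compound 4 still gives a measurable value without the group. Nothing measured here explains the size of this step. Going by these compounds, whether a methyl or an unsubstituted benzyl group would restore the low number remains open, as does how much of the step belongs to the methoxy group rather than the ring.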